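Swapping an aromatic ring for a saturated one

This account rests on a few compounds, and the source may have more. Where it says the series, first, only, none or still open, it means among the compounds named here.

compound 1 `O=c1cc(-c2ccccc2)oc2ccc(OCCCCCCN3CCCC(O)C3)cc12` — 86 nM
compound 2 `O=c1cc(-c2ccccc2Cl)oc2ccc(OCCCCCCN3CCC(O)CC3)cc12` — 47 nM

Of the compounds shown here, two share a core and have been measured in an assay on isolated protein (Cavia porcellus) with Sigma non-opioid intracellular receptor 1 (Homo sapiens) as the target, read by radioligand binding; a lower number here means a stronger inhibitor, a higher number a weaker inhibitor: compound 1 gives 86 nM and compound 2 gives 47 nM. Compound 2 has the lower of the two numbers, but its gap to compound 1 lies within the usual scatter, so the two cannot be told apart. Compound 3 `O=c1cc(C2CCCCC2)oc2ccc(OCCCCCCN3CCC(O)CC3)cc12` has not yet been measured. It differs from compound 2 in one place: cyclohexyl in place of 2-chlorophenyl on an aromatic carbon. Within the data shown here, no measured pair shows a change of this kind, so the expectation rests on the two numbers at hand alone. A small step toward a weaker inhibitor, or none beyond the scatter, seems the most likely outcome. Compound 3 is expected to give about 80 nM in this assay, with a range from 25 nM to 250 nM. This estimate means an expected step of a 1.7-fold higher number from compound 2 to compound 3 (0.23 log units; within the scatter).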

Compound 3, half-maximal inhibitory concentration: 88 nM
Compound 3: middle estimate off by 1.1-fold (0.04 log units), on the low side, within the range that was stated.
By their numbers in this assay, from the lowest: compounds 2, 1 and 3 (each within the scatter of the next).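

In this assay cyclohexyl in place of 2-chlorophenyl gives a 1.9-fold higher number from compound 2 to compound 3 (0.27 log units; within the scatter) and so leaves compound 2 and compound 3 indistinguishable. For this pair, then, the group on the aromatic carbon next to the ring oxygen need not be an aromatic ring: a non-aromatic ring of carbon alone reads the same within the scatter. No measurement at hand explains why the two compounds cannot be told apart.

This single change removes the chlorine and the aromatic ring together, so the pair cannot show what either contributes alone, and a result within the scatter could also hide a small real difference. From the compounds shown here alone, it is also open whether this position would read the same with a smaller carbon group, such as cyclopentyl or tert-butyl, or with a ring carrying an amine.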